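A few compounds are considered here, and "the series" means these few. Any claim that something is new, unique, unknown or untested is made for them only; others in the source may bear on it.

Working notes on the series

The series shares one core, with a phenoxymethyl group on the triazole ring varied at the position of the phenyl ring that is para to a large group. Compound 1 `O=c1cc(-n2cc(COc3ccccc3)nn2)c2cc(Br)ccc2o1` carries a hydrogen there; in a functional assay on SW480 cells (Homo sapiens) for antiproliferative activity, read by MTT assay, with a stated time of 48 h (on this read-out higher numbers stand for weaker inhibition and lower numbers for stronger inhibition), compound 1 gives 4990 nM. Compound 2 `O=c1cc(-n2cc(COc3ccc(Br)cc3)nn2)c2cc(Br)ccc2o1` carries a bromo group at the same place; in this assay compound 2 gives 1310 nM. Going by the values given here, the step of a 3.8-fold lower number from compound 1 to compound 2 (0.58 log units; beyond the scatter) is the only one measured so far, and compound 2 stands at the lower of the two numbers, with compound 1 as its only neighbour.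

Compound 3 `COC(=O)c1ccc(OCc2cn(-c3cc(=O)oc4ccc(Br)cc34)nn2)cc1` is not yet measured. It differs from compound 2 by methoxycarbonyl in place of bromo on an aromatic carbon. Among the compounds with values here, no measured step covers an exchange of one para substituent for another; the one measured step only shows that occupying the para position with bromo rather than hydrogen gave a modest move downwards. Whether a methoxycarbonyl group at the same place holds that gain, loses it or goes past it cannot be read from the two numbers in hand. The working expectation is that compound 3 lands between compound 1 and compound 2, with a step of a 1.9-fold higher number from compound 2 to compound 3 (0.28 log units; within the scatter), and on that basis compound 3 is estimated at 2500 nM in this assay, within a range of 800 nM to 8000 nM.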

Compound 3, half-maximal inhibitory concentration: 3620 nM
The estimate for compound 3 lay 1.4-fold (0.16 log units) below the measured number; measured number inside the range.
By their numbers in this assay, from the lowest: compound 2; then compounds 3 and 1 (each within the scatter of the next).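

The place para to a large group does not reward occupation as such. In this assay, methoxycarbonyl in place of bromo gives a 2.8-fold higher number from compound 2 to compound 3 (0.44 log units; beyond the scatter), so the gain seen with bromo does not carry over to every group placed there. Against the unsubstituted phenyl ring, methoxycarbonyl gives a 1.4-fold lower number from compound 1 to compound 3 (0.14 log units; within the scatter), which leaves compound 3 not separated from compound 1 and shows that this larger group, with its two hydrogen-bond acceptors, neither keeps the bromo gain nor produces a clear loss relative to hydrogen. No data in hand speak to why these two groups differ at this place.

From the compounds shown here alone, whether the gain belongs to bromo alone or is shared by other groups at the same place, such as chloro, methyl or methoxy, stays open, as does the response to a carboxylic acid or an amine there. Also open, going by these compounds, is whether the same ordering of compound 2, compound 3 and compound 1 would hold if the bromo on the shared core were exchanged for hydrogen or chloro.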